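The source may hold more compounds than are shown below. What is called first, only, known or untested is meant among the compounds shown, and "the series" means these compounds.

Compound 1, `ClCc1ccc(Cn2cnc3c(Cl)ncnc32)cc1`, and compound 2, `Nc1nc(Cl)c2ncn(Cc3ccc(CCl)cc3)c2n1`, share one core and differ only by amino in place of hydrogen on an aromatic carbon. In a functional assay on SNB-19 cells (Homo sapiens) for cytotoxicity, read by sulforhodamine B assay, with a stated time of 48 h (on this read-out lower numbers stand for higher toxicity in this test and higher numbers for lower toxicity in this test), compound 1 gives 89100 nM. In this assay compound 2 gives 46800 nM. The step between them is a 1.9-fold lower number from compound 1 to compound 2 (0.28 log units; within the scatter), so the two values cannot be told apart in this test. Compound 3, `ClCc1ccccc1Cn1cnc2c(Cl)ncnc21`, is made of the same atoms as compound 1 joined differently; the difference between the two cores is not broken down here. In this assay compound 3 reaches only a limit of the assay, > 100000 nM. It therefore sits at the limit of > 100000 nM in this assay, at which 1 of the 3 values shown sits. Compound 4, `Nc1nc(Cl)c2ncn(Cc3ccccc3CCl)c2n1`, has not yet been measured in this assay; it differs from compound 3 by amino in place of hydrogen on an aromatic carbon, the same change as that from compound 1 to compound 2. Because that change gave a 1.9-fold lower number from compound 1 to compound 2 (0.28 log units; within the scatter), compound 4 is expected to stay close to compound 3, with an estimated step that the limit leaves unreadable from compound 3 to compound 4. In this assay compound 4 is estimated at 110000 nM, with the likely range running from 50000 nM to 300000 nM.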

Compound 4, concentration lethal to 50% of the cells: > 100000 nM
Compound 4 ended at the assay's limit (the forecaster's own chance of this, stated with the estimate: 60%); the middle value does not contradict the limit.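

Compound 3 and compound 4 both stand at a limit of this assay rather than at a number, so no step from one to the other can be read: the limit of > 100000 nM in this assay, at which 2 of the 4 values shown sit.

The compounds shown leave open how far apart compound 3 and compound 4 really lie, and whether adding the amino group does the same here as in compound 2.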